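This account rests on a few compounds, and the source may have more. Where it says the series, first, only, none or still open, it means among the compounds named here.

Compound 1 `COc1ccc(-c2c(C)nn3c(NCc4ccc(C(N)=O)cc4)nc(C)cc23)cc1OC` and compound 2 `COc1ccc(-c2c(C)nn3c(NCc4cccnc4)nc(C)cc23)cc1OC` share one core, and they differ in a single group on a side chain. In a physicochemical assay for lipophilicity, at pH 7.4 (on this read-out lower numbers stand for lower lipophilicity and higher numbers for higher lipophilicity), compound 1 gives 4.8, and compound 2 gives 5.5. The change between them is pyridin-3-yl in place of 4-carbamoylphenyl on a saturated chain carbon bound to a nitrogen on an aromatic ring, and it produced a number 0.70 log units higher from compound 1 to compound 2 (beyond the scatter).

Compound 3 `COc1ccc(-c2c(C)nc3c(NCc4ccc(C(N)=O)cc4)nc(C)cn23)cc1OC` carries the same side chain as compound 1 but is built on a different core; the two share the same atoms joined differently, and the difference between the two cores is not broken down here. In this assay compound 3 gives 3.9, the lowest of the three measured numbers.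

Compound 4 `COc1ccc(-c2c(C)nc3c(NCc4cccnc4)nc(C)cn23)cc1OC` has not yet been measured. It stands to compound 3 as compound 2 stands to compound 1: the change is pyridin-3-yl in place of 4-carbamoylphenyl on a saturated chain carbon bound to a nitrogen on an aromatic ring, made at the same kind of place on a saturated chain carbon bound to a nitrogen on an aromatic ring. For the measured compounds named here, this is the same kind of change as the one from compound 1 to compound 2, though on the other core.

Because compound 3 sits at 3.9 and the earlier step was a number 0.70 log units higher from compound 1 to compound 2 (beyond the scatter), the step from compound 3 to compound 4 in this assay is expected to be a number 0.70 log units higher from compound 3 to compound 4 (beyond the scatter), a shift of about the same size. Going by the values given here, compound 4 is therefore estimated at 4.6 in this assay, with an expected range from 4.2 to 5; this rests on only one measured pair, so the transfer to a different core is an assumption.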

Compound 4, distribution coefficient: 4.5
Compound 4: the middle estimate sits 0.10 log units above what was measured; the range from low to high includes it.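

In this assay, putting pyridin-3-yl in place of 4-carbamoylphenyl gave a number 0.70 log units higher from compound 1 to compound 2 (beyond the scatter) on the core of compound 1, and the same change gave a number 0.60 log units higher from compound 3 to compound 4 (beyond the scatter) on the core of compound 3, so the number went up on both cores and the step was modest each time. This shows that, for these two cores, the size and direction of the step seen on one core gave a usable guide to the other, but two matched pairs are too few to make a general rule for other cores or for other changes to the side chain. No measurement shown here explains why the number rises in either pair.

The compounds shown leave open whether the step would look the same with other groups on a saturated chain carbon bound to a nitrogen on an aromatic ring, such as a plain phenyl, a phenyl bearing a carboxylic acid, or a morpholine ring. They also leave open what a longer chain leading to the pyridin-3-yl group would do, and whether the step would hold on any third core.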